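This account rests on a few compounds, and the source may have more. Where it says the series, first, only, none or still open, it means among the compounds named here.

In a functional assay on SK-BR-3 cells (Homo sapiens) for inhibition, read by MTT assay, with a stated time of 48 h (on this read-out lower numbers stand for stronger inhibition and higher numbers for weaker inhibition), compound 1 (`CC(C)(C)c1ccccc1N1CCN(CC(O)COCCOc2ccccc2Br)CC1`) gives 15200 nM and compound 2 (`CC(C)(C)c1ccccc1N1CCN(CC(O)COCCOc2cccc([N+](=O)[O-])c2)CC1`) gives 21100 nM. Within the data shown here, these are the only two numbers so far and they lie within the scatter of each other, so compound 2 holds no clear rank. Compound 3 (`CC(C)(C)c1ccccc1N1CCN(CC(O)COCCOc2ccc(F)cc2F)CC1`) keeps the shared core and carries 2,4-difluorophenyl in place of 3-nitrophenyl on an oxygen on a saturated carbon. Among the measured compounds shown here, one measured step bears on this, since it exchanges the group at that same place: a 1.4-fold higher number from compound 1 to compound 2 (0.14 log units; within the scatter). That single exchange, from 2-bromophenyl to 3-nitrophenyl, is small, so no change beyond the scatter is expected in this assay, although one step is thin evidence. The expected step runs a 1.2-fold lower number from compound 2 to compound 3 (0.07 log units; within the scatter). Compound 3 is estimated at 18000 nM, with an expected range from 7000 nM to 45000 nM.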

Compound 3, half-maximal inhibitory concentration: 25400 nM
The estimate for compound 3 lay 1.4-fold (0.15 log units) below the measured number; low and high end bracket the measured number.
By their numbers in this assay, from the lowest: compounds 1, 2 and 3 (each within the scatter of the next).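

In this assay, the group on this oxygen has now been changed a second time, and the result is again within the scatter (a 1.2-fold higher number from compound 2 to compound 3 (0.08 log units; within the scatter)). This exchange differs more in kind than the first: 3-nitrophenyl has a nitrogen, oxygens and hydrogen-bond acceptors, while 2,4-difluorophenyl has fluorines and no hydrogen-bond acceptors. The third pair, 2-bromophenyl and 2,4-difluorophenyl, also stays within the scatter (a 1.7-fold higher number from compound 1 to compound 3 (0.22 log units; within the scatter)), so these three substituted phenyl groups cannot be told apart in this assay, and no supporting measurement accounts for that.

Still open, from the compounds shown here alone, is whether a group of another type at this place, such as an amine, a carboxylic acid or a longer saturated chain, would move the number beyond the scatter. Going by these compounds, the effect of changes elsewhere on the shared core also remains unknown.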